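Adding a methyl to the chain of compound 2

The source may hold more compounds than are shown below. What is called first, only, known or untested is meant among the compounds shown, and "the series" means these compounds.

Measured in a physicochemical assay for pharmacokinetics, read by LC-MS, in phosphate buffer, tested at 1 uM; on this read-out higher numbers stand for a longer-lived compound and lower numbers for a shorter-lived compound:
- Compound 1 `CC#CCNC(=O)c1cccc2c1cc(C)n2-c1nc2c(c(NCc3ccccc3)n1)CCCC2`: > 24 h
- Compound 2 `CCC#CC(=O)Nc1cccc2c1cc(C)n2-c1nc2c(c(NCc3ccccc3)n1)CCCC2`: 13.5 h

The entry for compound 1 is a limit, not a number. For the measured compounds named here, compound 2 thus holds the only true number, 13.5 h. Compound 3 `CCCC#CC(=O)Nc1cccc2c1cc(C)n2-c1nc2c(c(NCc3ccccc3)n1)CCCC2` carries one change: methyl in place of hydrogen on a saturated chain carbon, two bonds along the chain from a triple-bonded carbon, which turns but-1-yn-1-yl into pent-1-yn-1-yl. Going by the values given here, the one measured step, an at least 1.7-fold lower number from compound 1 to compound 2 (0.24 log units; that floor lies within the scatter), exchanges a whole group on an aromatic carbon, so it bears only loosely on this small change. No step beyond the scatter is expected in this assay. The estimated step is a 1.0-fold higher number from compound 2 to compound 3 (0.02 log units; within the scatter). Compound 3 is expected at 14 h, with an estimated range of 8 h to 22 h.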

Compound 3, half-life: 21.6 h
Beside the measured number, compound 3's estimate is 1.5-fold (0.19 log units) below it; the range from low to high includes it.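

In this assay, for the compounds shown here, methyl in place of hydrogen on this saturated chain carbon gives the first step here between two true numbers, a 1.6-fold higher number from compound 2 to compound 3 (0.20 log units; within the scatter), so pent-1-yn-1-yl and but-1-yn-1-yl cannot be told apart on this read-out. The exchange of the whole group gives only a floor, an at least 1.1-fold lower number from compound 1 to compound 3 (0.04 log units; that floor lies within the scatter). The entry for compound 1 is a limit, not a number: the limit of > 24 h in this assay, at which 1 of the 3 values shown sits.

Going by these compounds, whether a longer chain or an amine at this carbon would give a step beyond the scatter remains open.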